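A few compounds are considered here, and "the series" means these few. Any claim that something is new, unique, unknown or untested is made for them only; others in the source may bear on it.

In a functional assay on Huh-7 cells (Homo sapiens) for cytotoxicity, read by MTT assay, with a stated time of 72 h (a higher number here means that more compound is tolerated, a lower number that less compound is tolerated), compound 1 `CS(=O)(=O)N1CCC2(CC1)OOC1(CCCCCC1)OO2` gives > 100 ug/mL, which is a limit and not an exact number. Compound 2 `CCCS(=O)(=O)N1CCC2(CC1)OOC1(CCCC1)OO2` gives > 100 ug/mL, also a limit. Compound 3 `CCCS(=O)(=O)N1CCC2(CC1)OOC1(CCCCC1)OO2` gives > 100 ug/mL, again a limit. Compound 1 thus stands at the limit of > 100 ug/mL in this assay, at which 3 of the 3 values shown sit. Compound 4 `O=S(=O)(CCCCl)N1CCC2(CC1)OOC1(CCCCCC1)OO2` keeps the core of compound 1 but carries 2-chloroethyl in place of hydrogen on a saturated chain carbon bound to a sulfonyl sulfur, so that methyl becomes 3-chloropropyl: 2-chloroethyl in place of hydrogen on a saturated chain carbon bound to a sulfonyl sulfur. Going by the values given here, no measured pair shows this change, so no step beyond the scatter is expected in this assay, in either direction, and the estimated step reads a number no higher from compound 1 to compound 4 (the limit leaves the size open). For compound 4 the expected value is 100 ug/mL, with an estimated range of 50 ug/mL to 200 ug/mL.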

Compound 4, half-maximal cytotoxic concentration: > 100 ug/mL
Compound 4: a limit, no number; the forecaster's own chance of this, stated with the estimate: 65%; the middle value lies on the limit itself.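

Going by these compounds alone, compound 1 and compound 4 each give only a limit, so no step between them can be read: the limit of > 100 ug/mL in this assay, at which 4 of the 4 values shown sit. The compounds shown leave open how far past that limit each one lies, and whether 3-chloropropyl in place of methyl changes the result at all.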